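Adding a Nitro Group to Compound 2

This account rests on a few compounds, and the source may have more. Where it says the series, first, only, none or still open, it means among the compounds named here.

Among the compounds with values here, in an ADME assay on L02 cells (Homo sapiens) for cytotoxicity, read by MTT assay, with a stated time of 24 h (a lower number here means a stronger inhibitor, a higher number a weaker inhibitor), compound 1 `O=C1/C(=C/c2cccnc2)CN(S(=O)(=O)c2ccccc2)C/C1=C\c1ccccc1F` gives 15300 nM and compound 2 `O=C1/C(=C/c2ccncc2)CN(S(=O)(=O)c2ccccc2)C/C1=C\c1ccccc1F` gives 15900 nM, so compound 2 stands level with its only measured neighbour, within the usual scatter. Compound 3 `O=C1/C(=C/c2ccncc2)CN(S(=O)(=O)c2ccc([N+](=O)[O-])cc2)C/C1=C\c1ccccc1F` keeps the rest of compound 2 but turns its phenyl into 4-nitrophenyl. The change is nitro in place of hydrogen on an aromatic carbon, with nitro in place of hydrogen on an aromatic carbon, para to a large group.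

Within the data shown here, only one measured step is available, a 1.0-fold higher number from compound 1 to compound 2 (0.02 log units; within the scatter), and it lies within the scatter. Among the measured compounds shown here, that step swaps pyridin-3-yl for pyridin-4-yl elsewhere in the molecule, and no measured compound carries a nitro group. The data therefore point in neither direction, and no change beyond the scatter is expected. The expected step is a 1.2-fold lower number from compound 2 to compound 3 (0.09 log units; within the scatter). In this assay, the estimate for compound 3 is 13000 nM, with an expected range of 5500 nM to 30000 nM.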

Compound 3, half-maximal inhibitory concentration: 18400 nM
Estimate against measurement, compound 3: 1.4-fold (0.15 log units) below, and the stated range covers the measured number.
By their numbers in this assay, from the lowest: compounds 1, 2 and 3 (each within the scatter of the next).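

In this assay, the step from the pyridine side of the molecule said nothing about the phenyl, and this pair now gives a first reading there: the change shows a 1.2-fold higher number from compound 2 to compound 3 (0.06 log units; within the scatter). A nitro group, with its 3 heavy atoms, can therefore replace hydrogen on this ring, para to a large group, without moving the number beyond the usual scatter of the assay. No measurement shown here explains this outcome.

On these data alone, this is a single group at a single place, so it remains open whether an amine or a carboxylic acid in the same spot would also stay level with compound 2. As far as these compounds go, it is equally open whether nitro would give the same result on compound 1, which carries pyridin-3-yl in place of pyridin-4-yl.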